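The compounds below may be only part of what the source reports. "The series", "measured", "known", "first", "only" and "open" are said of these compounds alone.

Compound 1 `COc1cc2c(cc1OC)C(CC(=O)O)CC2` and compound 2 `COc1cc2c(cc1OC)C(CC(N)=O)CC2` share a core and differ only at the carbonyl carbon, where the amino of compound 2 replaces the hydroxy of compound 1. In a functional assay on the whole organism (strain Wistar) for inhibition, with Rattus norvegicus as the target, read by paw edema, with stated times of 60 min and 1 h, at a dose of 100 mg/kg by the oral route (a lower number here means less inhibition, a higher number more inhibition at the dose given (going by the name of the read-out)), compound 1 gives 18.8%, and compound 2 gives 18.8%, so the two lie level no change at the digits printed from compound 1 to compound 2 (within the scatter). Within the data shown here, compound 2 therefore stands at the same level as its only measured neighbour, with no gap beyond the scatter between them.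

Compound 3 `CNC(=O)CC1CCc2cc(OC)c(OC)cc21` differs from compound 2 by methyl in place of hydrogen on an amide-type nitrogen. Among the measured compounds shown here, only one measured step bears on this change, the one from compound 1 to compound 2 at the carbonyl carbon, and it showed no movement beyond the scatter. Nothing measured here speaks for a shift in either direction from adding a methyl on the amide-type nitrogen, so for compound 3 no step beyond the scatter is expected a number 0.2 percentage points higher from compound 2 to compound 3 (within the scatter). Compound 3 is accordingly estimated at 19%, within 6% to 32%.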

Compound 3, a percentage reported as inhibition, in the whole organism at one dose (the size of the read-out at that dose, not a potency): 15.6%
For compound 3 the middle estimate is 3.4 percentage points above the measured one, within the range that was stated.
By their numbers in this assay, from the lowest: compounds 3, 1 and 2 (each within the scatter of the next).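

In this assay, among these compounds, the amide-type nitrogen itself is varied for the first time, and methyl in place of hydrogen there gives a number 3.2 percentage points lower from compound 2 to compound 3 (within the scatter). Methylamino in place of hydroxy on the carbonyl carbon reads the same way, with a number 3.2 percentage points lower from compound 1 to compound 3 (within the scatter). The hydroxy, amino and methylamino groups on this carbonyl carbon therefore stand within the scatter of one another at this single dose, which extends the flat picture from the carbonyl carbon to the nitrogen. No available evidence bears on this result.

From the compounds shown here alone, whether a longer chain on the nitrogen, such as ethyl or benzyl, or a second methyl there, would separate from these three compounds remains open. So does the effect of an amine in place of the carbonyl group.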